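Compound 4: chlorine in place of the side chain

The compounds below may be only part of what the source reports. "The series", "measured", "known", "first", "only" and "open" are said of these compounds alone.

Values in an ADME assay on blood (Rattus norvegicus) for metabolic stability, with a stated time of 2 h; on this read-out higher numbers stand for a more stable compound and lower numbers for a less stable compound:
- compound 1 `CCC(=O)c1ccc(N(C)C(=O)CSc2nnc(CNc3ccccc3)n2CC)cc1`: 1.9%
- compound 2 `CC/C(=N/OC)c1ccc2oc(CSc3nnc(CNc4ccccc4)n3CC)nc2c1`: "not determined" (no result reported)
- compound 3 `CCC(=O)c1ccc2nc(CSc3nnc(CNc4ccccc4)n3CC)oc2c1`: 35%

Compound 2 has no single number on this read-out, so its standing among the others cannot be placed. Compound 4 `CCn1c(CNc2ccccc2)nnc1SCc1nc2cc(Cl)ccc2o1` comes from compound 2 through (one chlorine atom in place of a group of 6 heavy atoms (4 carbon, 1 nitrogen, 1 oxygen; no ring), on an aromatic carbon). The chlorine sits on the six-membered aromatic ring of carbon only, part of the fused system of two rings.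

Among the measured compounds shown here, the data hold no step between measured compounds that differ in one place, and the step from compound 2 has no starting value. Any expectation for this assay therefore rests on the two numbers available. Compound 1 gives 1.9%, a lower value than compound 3 at 35%. Compound 3 has a fused system of two rings, as compound 4 does, whereas compound 1 does not, so compound 3 is the nearer reference. Against compound 3, no step beyond the usual scatter is expected in either direction, although this expectation is weakly supported. For compound 4 the estimated value is 38%, with an expected range of 12% to 70%.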

Compound 4, percent of the compound remaining: 92%
Estimate against measurement, compound 4: 54 percentage points below, outside the stated range (above it).
By their numbers in this assay, from the lowest: compound 1; then compound 3; then compound 4.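

In this assay compound 2 has no single number, so the step from it to compound 4 at 92% cannot be read. No available evidence bears on the value of compound 4.

The compounds shown leave open whether the chloro group or another feature of compound 4 goes with its value.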